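A few compounds are considered here, and "the series" means these few. Any claim that something is new, unique, unknown or untested is made for them only; others in the source may bear on it.

Compound 2 `COc1cc(OC)c(C(=O)/C=C/c2ccccc2)c(OC)c1` shares its core with compound 1 `COc1cccc(/C=C/C(=O)c2c(OC)cc(OC)cc2OC)c1`. For the measured compounds named here, in a functional assay on NCI-H727 cells (Homo sapiens), read by fluorescence and BrdU incorporation, with a stated time of 48 h, tested at 25 uM (on this read-out lower numbers stand for a stronger effect and higher numbers for a weaker effect at the one concentration tested), compound 2 gives 4.5%, the lowest of the two numbers measured so far, and compound 1 gives 5.1%. Going by the values given here, the only step between measured compounds, a number 0.6 percentage points lower from compound 1 to compound 2 (within the scatter), is within the scatter, so the two read alike on this assay.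

Compound 3 `COc1cc(OC)c(C(=O)/C=C/c2ccc(Cl)cc2)c(OC)c1` is the next compound to be tested. It differs from compound 2 by chloro in place of hydrogen on an aromatic carbon. Among the compounds with values here, the one measured step that bears on this change is the one from compound 1 to compound 2, which also touched a single aromatic carbon of the core and left the read-out where it was. On that basis one expects no step beyond the scatter in this assay from compound 2 to compound 3, that is, an estimated step of a number 0.5 percentage points higher from compound 2 to compound 3 (within the scatter).

Compound 3 is therefore expected to give about 5% in this assay, most likely between 0% and 15%.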

Compound 3, a percentage reported as activity, at one concentration (the size of the read-out at that concentration, not a potency): 0%
Compound 3: the middle estimate sits 5 percentage points above what was measured; measured number inside the range.
By their numbers in this assay, from the lowest: compounds 3, 2 and 1 (each within the scatter of the next).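

In this assay, the change from phenyl to 4-chlorophenyl, which puts chloro on an aromatic carbon para to a large group, amounts to a number 4.5 percentage points lower from compound 2 to compound 3 (within the scatter). For the compounds shown here, this is the first view of this position, and it shows that a single chlorine atom there leaves the read-out within the scatter of the unsubstituted compound; the exchange of 3-methoxyphenyl for 4-chlorophenyl, a number 5.1 percentage points lower from compound 1 to compound 3 (within the scatter), is likewise within the scatter, so all three aromatic end groups read alike in this assay. No evidence is available on what lies behind this result.

The three compounds shown therefore mark no change at this aromatic ring that moves the read-out beyond the scatter, and they do not show how far this tolerance extends, since chloro is the only group tested at this position. From the compounds shown here alone, a carboxylic acid or a dimethylamino group on the same carbon, or a longer chain such as butoxy, could still separate from compound 3 at 0%, and the shared core itself remains untested by these steps.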